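The source may hold more compounds than are shown below. What is called first, only, known or untested is meant among the compounds shown, and "the series" means these compounds.

In a functional assay on A-375 cells (Homo sapiens) for activation, with a stated time of 3 days (a lower number here means that less compound is needed, a higher number that more compound is needed for the effect), compound 1 `O=C(NC1CCCN(Cc2ccc(F)c(F)c2)C1)c1ccc(-c2cscn2)cc1` reads > 20000 nM as a limit of the assay, not a number. Within the data shown here, compound 2 `O=C(Nc1ccc(-c2ccccn2)cc1)C1CCCN(Cc2ccc(F)c(F)c2)C1` gives 11000 nM and compound 3 `O=C(Nc1ccc(-c2ccn[nH]2)cc1)C1CCCN(Cc2ccc(F)c(F)c2)C1` gives 580 nM as the lowest number so far. Compound 4 `O=C(Nc1ccc(-c2ccc[nH]2)cc1)C1CCCN(Cc2ccc(F)c(F)c2)C1` differs from compound 3 in one group, with 1H-pyrrol-2-yl in place of 1H-pyrazol-5-yl on an aromatic carbon as the counted change: 1H-pyrrol-2-yl in place of 1H-pyrazol-5-yl on an aromatic carbon. Among the measured compounds shown here, only one measured step bears on this, a 19-fold lower number from compound 2 to compound 3 (1.28 log units; beyond the scatter) at this same place, and it is large. The new group is again a five-membered aromatic ring, so only part of that gain is expected to be lost. In this assay the expected shift is a 2.6-fold higher number from compound 3 to compound 4 (0.41 log units; beyond the scatter) toward a higher number. For compound 4 the estimated value is 1500 nM with an expected range from 350 nM to 6500 nM in this estimate.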

Compound 4, half-maximal effective concentration: 720 nM
The estimate for compound 4 lay 2.1-fold (0.32 log units) above the measured number; measured number inside the range.
By their numbers in this assay, from the lowest: compounds 3 and 4 (each within the scatter of the next); then compound 2. At a limit, above all of these: compound 1.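

Replacing 1H-pyrazol-5-yl with 1H-pyrrol-2-yl in this assay gives a 1.2-fold higher number from compound 3 to compound 4 (0.09 log units; within the scatter), so the hydrogen-bond acceptor counted on the leaving ring can go from this position without a change beyond the scatter. The replacement of pyridin-2-yl gives a 15-fold lower number from compound 2 to compound 4 (1.18 log units; beyond the scatter), which shows that the earlier gain is not confined to 1H-pyrazol-5-yl. Nothing measured here explains this gain. As far as these compounds go, it remains open how furan-2-yl or 1-methyl-1H-pyrrol-2-yl would read at this position, and therefore whether the hydrogen on the ring nitrogen matters.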